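Halogen Swap at the Para Position: Chloro to Bromo

This account rests on a few compounds, and the source may have more. Where it says the series, first, only, none or still open, it means among the compounds named here.

Measured so far:
compound 1 `c1ccc(-c2cn3ccnc3c(-c3ccc4ncn(C5CCCCC5)c4c3)n2)cc1` gives 44.4% in a functional assay on SNB-75 cells (Homo sapiens) for inhibition, read by sulforhodamine B assay, with a stated time of 48 h, tested at 10 uM; a lower number here means less inhibition, a higher number more inhibition at the concentration tested (going by the name of the read-out);
compound 2 `Clc1ccc(-c2cn3ccnc3c(-c3ccc4ncn(C5CCCCC5)c4c3)n2)cc1` gives 31.2%.

On these two numbers compound 2 stands lowest, and compound 1 sits above it by a number 13.2 percentage points lower from compound 1 to compound 2 (beyond the scatter). Compound 3 `Brc1ccc(-c2cn3ccnc3c(-c3ccc4ncn(C5CCCCC5)c4c3)n2)cc1` is the next step, differing from compound 2 by bromo in place of chloro on an aromatic carbon. Among the compounds with values here, no measured step exchanges one halogen for another, so the one step known, chloro replacing hydrogen, only shows that the number in this assay came out lower with a halogen on this ring; it says nothing about exchanging chloro for bromo. A step of no more than the usual scatter is therefore expected, a number 1.2 percentage points lower from compound 2 to compound 3 (within the scatter). Compound 3 is estimated at 30%, within 15% to 45%.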

Compound 3, a percentage reported as inhibition, at one concentration (the size of the read-out at that concentration, not a potency): 34.6%
Estimate against measurement, compound 3: 4.6 percentage points below; the measured number falls inside the stated range.
By their numbers in this assay, from the lowest: compounds 2, 3 and 1 (each within the scatter of the next, the first and the last beyond it).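

Exchanging chloro for bromo at this position gives a number 3.4 percentage points higher from compound 2 to compound 3 (within the scatter) in this assay and so the two halogens cannot be told apart there. Bromo in place of hydrogen gives a number 9.8 percentage points lower from compound 1 to compound 3 (within the scatter) and so, of the two halogen compounds, only compound 2 stands clearly apart from compound 1. Nothing available explains why the numbers fall this way.

Going by these compounds, whether fluoro would fit with chloro and bromo remains open. So does what a group other than a halogen, such as an amine or a carboxylic acid, would do on this aromatic carbon.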